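Trading Fluorines for a Nitro Group on the Amine Arm

The source may hold more compounds than are shown below. What is called first, only, known or untested is meant among the compounds shown, and "the series" means these compounds.

Measured compounds and their values in a functional assay, with a stated time of 6 min; a higher number here means a weaker inhibitor, a lower number a stronger inhibitor:
- compound 1, `CCCCCCCCCCCCCCCCNCn1nc(-c2ccc3c(c2)OCCO3)oc1=S`: 22900 nM
- compound 2, `Fc1cc(NCn2nc(-c3ccc4c(c3)OCCO4)oc2=S)cc(F)c1F`: 2920 nM
- compound 3, `FC(F)(F)c1cc(NCn2nc(-c3ccc4c(c3)OCCO4)oc2=S)cc(C(F)(F)F)c1`: 9320 nM

All three share the same core; they differ only in the group carried on the amine nitrogen. Compound 2, with its 3,4,5-trifluorophenyl group, gives the lowest number of the three in this assay and is therefore the strongest inhibitor shown: compound 3 sits beyond the usual scatter above it, and compound 1, which carries a long saturated chain instead of an aromatic ring, lies further away still.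

Compound 4, `O=[N+]([O-])c1ccccc1NCn1nc(-c2ccc3c(c2)OCCO3)oc1=S`, has not yet been measured. Its change from compound 2 is 2-nitrophenyl in place of 3,4,5-trifluorophenyl on an amine nitrogen. Both aromatic groups seen so far give lower numbers than the chain of compound 1, so an aromatic group on the amine nitrogen seems to matter, but nothing measured tells how a nitro group compares with fluorines here. The step from compound 2 to compound 4 in this assay is therefore expected to be modest, most likely a weakening that may or may not exceed the scatter. The estimate for compound 4 is 5500 nM, with a range from 1500 nM to 18000 nM, which means an expected step of a 1.9-fold higher number from compound 2 to compound 4 (0.27 log units; within the scatter).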

Compound 4, half-maximal inhibitory concentration: 10900 nM
Compound 4: the middle estimate sits 2.0-fold (0.30 log units) below what was measured, within the range that was stated.
By their numbers in this assay, from the lowest: compound 2; then compounds 3 and 4 (each within the scatter of the next); then compound 1.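

In this assay, exchanging 3,4,5-trifluorophenyl for 2-nitrophenyl on the amine nitrogen gives a 3.7-fold higher number from compound 2 to compound 4 (0.57 log units; beyond the scatter), so this change weakens inhibition by more than the usual scatter. Both groups have 9 heavy atoms and one six-membered aromatic ring of carbon only, so having an aromatic ring of this size on the nitrogen does not by itself fix the value; the atoms attached to that ring matter too. The earlier compounds could not show this, as no two of them formed a listed step, whereas this pair offers a direct comparison of two aromatic groups at this position.

The change removes three fluorines and adds a nitro group with 2 hydrogen-bond acceptors, but no available evidence identifies which of these differences accounts for the weaker inhibition.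

An unsubstituted phenyl group would help to show whether the fluorines improve inhibition, the nitro group worsens it, or both. A 2-fluorophenyl group would separate the effect of the number of substituents from that of their identity, and a 4-nitrophenyl group would test whether the location of the nitro group matters.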